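The compounds below may be only part of what the source reports. "The series", "measured", "known", "first", "only" and "open" are said of these compounds alone.

Measured so far:
Compound 1 `COc1ccc(CNc2nc(SC)nc3ncccc23)cc1`; in a functional assay on HT-29 cells (Homo sapiens) for cytotoxicity, read by MTT assay, with a stated time of 72 h (on this read-out lower numbers stand for stronger inhibition of growth and higher numbers for weaker inhibition of growth), compound 1 gives > 100000 nM, which is a limit of the assay and not a number.
Compound 2 `CSc1nc(NCCCCCO)c2cccnc2n1`; in this assay compound 2 gives 63900 nM.

Among the measured compounds shown here, compound 2 carries the only actual number in this assay; the other value shown is a limit. Compound 1 sits at the limit of > 100000 nM in this assay, at which 1 of the 2 values shown sits. The step under consideration goes from compound 2 to compound 3 `CSc1nc(NCc2ccccc2)c2cccnc2n1`, namely (phenyl in place of 4-hydroxybutyl on a saturated chain carbon bound to a nitrogen on an aromatic ring). For the measured compounds named here, no step between two measured compounds is available, so the size of this change has no anchor in measured pairs. In this assay the expectation for compound 3 is a move toward weaker inhibition of growth, with a step of about a 1.6-fold higher number from compound 2 to compound 3 (0.19 log units; within the scatter) expected, and a real chance that only a limit is returned. Compound 3 is estimated at 100000 nM, expected to fall between 40000 nM and 250000 nM.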

Compound 3, concentration for 50% growth inhibition: 87100 nM
Compound 3: the middle estimate sits 1.1-fold (0.06 log units) above what was measured; the range from low to high includes it.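

In this assay, the exchange on a saturated chain carbon bound to a nitrogen on an aromatic ring gives a 1.4-fold higher number from compound 2 to compound 3 (0.13 log units; within the scatter), so phenyl and 4-hydroxybutyl cannot be told apart at this place, even though a chain with no ring gives way to a six-membered aromatic ring of carbon only. Hydrogen in place of methoxy on an aromatic carbon gives an at least 1.1-fold lower number from compound 1 to compound 3 (0.05 log units; that floor lies within the scatter), so the loss of methoxy shows no change beyond the scatter. Compound 1 gives a limit of the assay and not a number: the limit of > 100000 nM in this assay, at which 1 of the 3 values shown sits.

Going by these compounds, whether an amine, a carboxylic acid or a longer chain at this place would move the number beyond the scatter stays open. On these data alone, the true size of the methoxy step also stays open, with only a floor available for it.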